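Swapping the aryl group on an amidine core of a receptor ligand

This account rests on a few compounds, and the source may have more. Where it says the series, first, only, none or still open, it means among the compounds named here.

Three close relatives of one scaffold have been measured in an assay on LM cells for displacement of a labelled ligand from Neuropeptide Y receptor type 5 (Homo sapiens); on this read-out higher numbers stand for weaker inhibition and lower numbers for stronger inhibition. Compound 1 `Fc1ccc(C2(c3ccc(F)cc3)CNC(c3ccccc3)=N2)cc1` gives 32 nM. Compound 2 `O=Cc1cccc(C2=NC(c3ccc(F)cc3)(c3ccc(F)cc3)CN2)c1` gives 8.7 nM, and compound 3 `Fc1ccc(C2(c3ccc(F)cc3)CNC(c3cccnc3)=N2)cc1` gives 7.2 nM. Among these three numbers compound 2 holds the second highest; its nearest neighbour is compound 3, at a distance within the scatter, and its furthest is compound 1, beyond the scatter.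

The step of interest leads from compound 2 to compound 4 `N#Cc1cccc(C2=NC(c3ccc(F)cc3)(c3ccc(F)cc3)CN2)n1`. The change is 6-cyanopyridin-2-yl in place of 3-formylphenyl on a carbon with a double bond to nitrogen.

Among the measured compounds shown here, two measured steps bear on this. Exchanging the phenyl for a pyridin-3-yl on the same carbon gave a 4.4-fold lower number from compound 1 to compound 3 (0.65 log units; beyond the scatter). Exchanging 3-formylphenyl for pyridin-3-yl gave a 1.2-fold lower number from compound 2 to compound 3 (0.08 log units; within the scatter). Both show that the aryl group on this carbon can be varied with only small to modest effects, and that a ring nitrogen in place of a formyl-bearing carbon ring changes little. For the measured compounds named here, the entering 6-cyanopyridin-2-yl has no measured precedent, so a step within the scatter, or at most a modest one in either direction, is expected. The expected step is a 1.4-fold higher number from compound 2 to compound 4 (0.14 log units; within the scatter). Compound 4 is therefore estimated at 12 nM, with a range from 3 nM to 50 nM.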

Compound 4, half-maximal inhibitory concentration: 39 nM
Compound 4: the middle estimate sits 3.3-fold (0.51 log units) below what was measured, within the range that was stated.
By their numbers in this assay, from the lowest: compounds 3 and 2 (each within the scatter of the next); then compounds 1 and 4 (each within the scatter of the next).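

In this assay, this carbon proves less forgiving than the earlier compounds suggested: 6-cyanopyridin-2-yl gives a 4.5-fold higher number from compound 2 to compound 4 (0.65 log units; beyond the scatter) and a 5.4-fold higher number from compound 3 to compound 4 (0.73 log units; beyond the scatter), whereas each earlier step shown at this carbon went to a lower number or stayed within the scatter. Against the plain phenyl group the change gives a 1.2-fold higher number from compound 1 to compound 4 (0.09 log units; within the scatter), so the advantage over phenyl shared by 3-formylphenyl and pyridin-3-yl does not extend to every ring carrying a nitrogen or a substituent, and 6-cyanopyridin-2-yl ends up level with phenyl. Nothing measured here explains this difference between the aryl groups.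

The entering group differs from both 3-formylphenyl and pyridin-3-yl in more than one feature, so these compounds cannot separate the contribution of the nitrile from that of the ring nitrogen's placement. Plain pyridin-2-yl and 3-cyanophenyl would pull those two features apart, while a ring bearing an amine or a carboxylic acid would show whether groups of a different kind are accepted on this aryl ring.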